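Exchanging the benzyl halogens in a chloro-aryl thioenone series

This account rests on a few compounds, and the source may have more. Where it says the series, first, only, none or still open, it means among the compounds named here.

Compound 3 `CN(C)c1ccc(/C=C(/SCc2ccc(Cl)c(Cl)c2)C(=O)c2ccc(Cl)cc2)cc1` sits in a functional assay on DU-145 cells (Homo sapiens) for inhibition, read by trypan blue exclusion, with a stated time of 96 h (a higher number here means a weaker inhibitor of growth, a lower number a stronger inhibitor of growth), at 50000 nM. Compound 2 `Cc1ccsc1/C=C(/SCc1ccc(F)cc1)C(=O)c1ccc(Cl)cc1` gives 50000 nM in this assay, so compound 3 stands level with it within the scatter. Compound 1 `Cc1ccc(CS/C(=C/c2ccc(N(C)C)cc2)C(=O)c2ccc(Cl)cc2)cc1` reaches only the assay limit of > 100000 nM in this assay. Among the measured compounds shown here, the one measured step that bears on the change, an at least 2.0-fold lower number from compound 1 to compound 3 (0.30 log units; that floor lies within the scatter), is bounded by the limit of > 100000 nM in this assay, at which 1 of the 3 values shown sits, and so says little beyond the scatter. Compound 4 `CN(C)c1ccc(/C=C(/SCc2ccc(F)cc2)C(=O)c2ccc(Cl)cc2)cc1` differs from compound 3 by 4-fluorophenyl in place of 3,4-dichlorophenyl on a saturated chain carbon bound to a sulfur. Compound 2 carries the same 4-fluorobenzyl group and gives 50000 nM, which argues for no step beyond the scatter. Compound 4 is therefore expected near 60000 nM, between 20000 nM and 150000 nM, a step of a 1.2-fold higher number from compound 3 to compound 4 (0.08 log units; within the scatter) that is expected to stay within the scatter.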

Compound 4, concentration for 50% growth inhibition: 50000 nM
Estimate against measurement, compound 4: 1.2-fold (0.08 log units) above; the measured number falls inside the stated range.
By their numbers in this assay, from the lowest: compounds 2, 3 and 4 (each within the scatter of the next). At a limit, above all of these: compound 1.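

Replacing 3,4-dichlorophenyl with 4-fluorophenyl at this saturated chain carbon bound to a sulfur gives a step that stays within the scatter (no change at the digits printed from compound 3 to compound 4 (within the scatter)). With 4-fluorobenzyl held fixed, 4-(dimethylamino)phenyl in place of 3-methylthiophen-2-yl also stays within the scatter (no change at the digits printed from compound 2 to compound 4 (within the scatter)). The remaining step (an at least 2.0-fold lower number from compound 1 to compound 4 (0.30 log units; that floor lies within the scatter)) gives only a floor set by a limit: the limit of > 100000 nM in this assay, at which 1 of the 4 values shown sits. Left open is whether an amine or a carboxylic acid on this phenyl group, or a longer chain in place of the benzyl group, would give a step beyond the scatter.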